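Swapping 4-fluorophenyl for 2-methoxyphenyl on the shared core

This account rests on a few compounds, and the source may have more. Where it says the series, first, only, none or still open, it means among the compounds named here.

Compound 1 `CCn1cc(-c2nnc(SCc3nnc(-c4ccc(F)cc4)o3)[nH]2)c(=O)c2cc(F)c(N3CCN(C)CC3)cc21` gives 3800 nM
Compound 2 `CCn1cc(-c2nc(SCc3nnc(-c4ccc(F)cc4)o3)n(CN(C)C)n2)c(=O)c2cc(F)c(N3CCN(C)CC3)cc21` gives 1500 nM

In a functional assay on HL-60 cells (Homo sapiens) for antiproliferative activity (on this read-out higher numbers stand for weaker inhibition and lower numbers for stronger inhibition), compound 1 stands at 3800 nM and so holds the higher of the two numbers, while compound 2 at 1500 nM lies lower by a gap beyond the usual scatter.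

Compound 3 `CCn1cc(-c2nnc(SCc3nnc(-c4ccccc4OC)o3)[nH]2)c(=O)c2cc(F)c(N3CCN(C)CC3)cc21` has not yet been measured. It keeps the core of compound 1 and carries 2-methoxyphenyl in place of 4-fluorophenyl on an aromatic carbon of a five-membered aromatic ring with 2 nitrogen and 1 oxygen. Within the data shown here, no measured pair shows what this exchange does, so the only guide is compound 1 with its 3800 nM as the anchor. On that basis, no shift beyond the scatter is expected in this assay in either direction. The expected change is a 1.3-fold lower number from compound 1 to compound 3 (0.10 log units; within the scatter) and would be a small one. For compound 3 the estimated value is 3000 nM with an expected range from 1200 nM to 8000 nM in this measurement.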

Compound 3, half-maximal inhibitory concentration: 3800 nM
For compound 3 the middle estimate is 1.3-fold (0.10 log units) below the measured one; the range from low to high includes it.
By their numbers in this assay, from the lowest: compound 2; then compounds 1 and 3 (each within the scatter of the next).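

In this assay, the exchange of 4-fluorophenyl for 2-methoxyphenyl on an aromatic carbon of the five-membered aromatic ring with 2 nitrogen and 1 oxygen shows no change at the digits printed from compound 1 to compound 3 (within the scatter). Among these compounds, this is the first direct reading at this position, since compound 1 and compound 2 both carry 4-fluorophenyl and so said nothing about what a different aryl group does there. The entering group brings a hydrogen-bond acceptor that the leaving group lacks, yet the exchange as a whole does not register on this read-out, and nothing available here offers an explanation for that result.

What the compounds shown leave open is whether this position stays equally flat with groups of another kind, such as a carboxylic acid or an amine on the phenyl ring, or a longer alkyl chain in place of the phenyl ring altogether. They also leave open whether 2-methoxyphenyl would give the same outcome on the core of compound 2, and whether a single exchange of this sort says anything general about the position.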